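The source may report more compounds than this note shows. Statements on the series, on what has been measured and on what is new or still open speak of the compounds shown alone.

Measured compounds:
- Compound 1 `ClCc1ccccc1Cn1cnc2c(Cl)nc(Cl)nc21` — 1540 nM
- Compound 2 `ClCc1ccc(Cn2cnc3nc(Cl)nc(Cl)c32)cc1` — 9120 nM
- Compound 3 `ClCc1cccc(Cn2cnc3nc(Cl)nc(Cl)c32)c1` — 2450 nM

In a functional assay on SK-MEL-5 cells (Homo sapiens) for cytotoxicity, read by sulforhodamine B assay, with a stated time of 48 h (a lower number here means a stronger inhibitor of growth, a higher number a weaker inhibitor of growth), compound 1 gives 1540 nM. Compound 3, which gives 2450 nM, sits within the usual scatter of compound 1, so the two cannot be told apart on these numbers. Compound 2, at 9120 nM, lies beyond the scatter, so compound 1 and compound 3 both give clearly lower numbers than compound 2. Compound 1 thus stands at the low end of the three, sharing that position with compound 3.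

Compound 4 `Nc1nc(Cl)c2ncn(Cc3ccccc3CCl)c2n1` has not yet been measured. It differs from compound 1 in one place: amino in place of chloro on an aromatic carbon. Going by the values given here, no pair of measured compounds shows this change, so there is no measured step to lean on, and the expectation rests on compound 1 alone. The step from compound 1 to compound 4 is expected to be modest, most likely toward a somewhat higher number, as a 1.9-fold higher number from compound 1 to compound 4 (0.29 log units; within the scatter). Compound 4 is estimated to give 3000 nM, with a range from 1000 nM to 10000 nM.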

Compound 4, concentration for total growth inhibition: 26300 nM
Beside the measured number, compound 4's estimate is 8.8-fold (0.94 log units) below it; measured number above the stated range.
By their numbers in this assay, from the lowest: compounds 1 and 3 (each within the scatter of the next); then compound 2; then compound 4.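

This position does not tolerate every replacement equally. In this assay, amino in place of chloro on an aromatic carbon between two ring nitrogen atoms gives a 17-fold higher number from compound 1 to compound 4 (1.23 log units; beyond the scatter), a large step in the direction of weaker growth inhibition. Compounds 1, 2 and 3 all carry chloro here, so only this step shows that the number depends on the group at this position, and no measurement shown here accounts for its size.

The compounds shown leave open whether a hydroxyl, a methoxy or a methylamino group at this position would give a number nearer that of compound 1 or that of compound 4. They also leave open whether amino in place of chloro would produce a step of similar size on compound 2 or compound 3.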